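This account rests on a few compounds, and the source may have more. Where it says the series, first, only, none or still open, it means among the compounds named here.

Compound 3 `COc1ccc(NC(=O)/C=C/c2coc3cc(OC)ccc3c2=O)cc1` is the only one of the three measured compounds to return an actual number: in a functional assay on A549 cells (Homo sapiens) for inhibition, read by MTT assay, with a stated time of 48 h (a lower number here means a stronger inhibitor, a higher number a weaker inhibitor), compound 3 gives 23000 nM. Compound 1 `COc1ccc2c(=O)c(/C=C/C(=O)Nc3cccc(C)c3)coc2c1` reaches only the limit of this assay, giving > 100000 nM. Compound 2 `COc1ccc2c(=O)c(/C=C/C(=O)NCc3ccccc3F)coc2c1` likewise sits at the limit, giving > 100000 nM. Both steps toward compound 3 are therefore known only as at least a certain size: an at least 4.3-fold lower number from compound 1 to compound 3 (0.63 log units; beyond the scatter) and an at least 4.3-fold lower number from compound 2 to compound 3 (0.63 log units; beyond the scatter). Between compound 1 and compound 2 the two limits leave the step unreadable, as a step that the two limits leave unreadable from compound 1 to compound 2 states, and this is simply a consequence of the limit of > 100000 nM in this assay, at which 2 of the 3 values shown sit.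

Compound 4 `COc1ccc2c(=O)c(/C=C/C(=O)Nc3ccc(Cl)cc3)coc2c1` has not yet been measured. It differs from compound 3 in one place: chloro in place of methoxy on an aromatic carbon. Within the data shown here, no measured step exchanges a methoxy for a chloro, so the only guidance is that the 4-methoxyphenyl amide of compound 3 did better than the 3-methylphenyl of compound 1 and the 2-fluorobenzyl of compound 2. On these data alone, whether a 4-chlorophenyl keeps that gain is unknown, so no step beyond the scatter is expected. The expected step is a 1.3-fold higher number from compound 3 to compound 4 (0.12 log units; within the scatter). Compound 4 is therefore estimated at 30000 nM, with a range from 8000 nM to 150000 nM.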

Compound 4, half-maximal inhibitory concentration: > 100000 nM
Compound 4 gave a limit, no number; the forecaster's own chance of this, stated with the estimate: 25%; at least 3.3-fold (0.52 log units) between middle value and limit.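

Among these compounds, compound 3 and compound 4 differ only in the group on an aromatic carbon para to a large group, so this pair isolates a single place, whereas the earlier comparisons exchanged the whole substituent on the amide nitrogen. In this assay, replacing methoxy with chloro there gives an at least 4.3-fold higher number from compound 3 to compound 4 (0.63 log units; beyond the scatter), so a phenyl amide with a group at this place is not enough on its own, and the identity of that group matters. The steps to compound 4 from compound 1 and from compound 2 cannot be read because both ends of each step are limits, not numbers: the limit of > 100000 nM in this assay, at which 3 of the 4 values shown sit.

The compounds shown compare only methoxy and chloro at this place, so it remains open whether an amine, a hydroxyl group or a longer chain such as ethoxy would give a readable number in this assay. On these data alone, the true size of the step from methoxy to chloro also remains open, as does whether methoxy would keep its readable number on another carbon of the same ring.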